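From benzyl to 3,5-dichlorobenzyl: a clearance estimate

The source may hold more compounds than are shown below. What is called first, only, known or untested is meant among the compounds shown, and "the series" means these compounds.

- compound 1 `CS(=O)(=O)NC(=O)c1cc(C2CC2)c(OCC2CCN(C(=O)c3cc(Cl)cc(Cl)c3)CC2)cc1F`: 8.6 mL/min/kg
- compound 2 `CS(=O)(=O)NC(=O)c1cc(C2CC2)c(OCC2CCN(Cc3ccc(Cl)cc3)CC2)cc1F`: 9.9 mL/min/kg
- compound 3 `CS(=O)(=O)NC(=O)c1cc(C2CC2)c(OCC2CCN(Cc3ccccc3)CC2)cc1F`: 4.8 mL/min/kg

All three values come from an ADME assay on microsomes from liver (Homo sapiens) for metabolic stability, read by LC-MS, using NADPH, with a stated time of 60 min, tested at 1 uM; on this read-out lower numbers stand for slow clearance and higher numbers for fast clearance. Compound 3 sits within the scatter of compound 1, while its gap to compound 2 lies just beyond the scatter. Compound 4 `CS(=O)(=O)NC(=O)c1cc(C2CC2)c(OCC2CCN(Cc3cc(Cl)cc(Cl)c3)CC2)cc1F` differs from compound 3 by 3,5-dichlorophenyl in place of phenyl on a saturated chain carbon bound to an amine nitrogen in a ring, with 3,5-dichlorophenyl in place of phenyl. The closest guide is the modest step of a 2.1-fold lower number from compound 2 to compound 3 (0.31 log units; beyond the scatter), with hydrogen in place of chloro on an aromatic carbon. The step of a 1.8-fold lower number from compound 1 to compound 3 (0.25 log units; within the scatter) stays within the scatter. Among the measured compounds shown here, no measured compound carries the 3,5-dichlorobenzyl group. Adding chloro is therefore expected to raise the number, and the estimated step is a 1.9-fold higher number from compound 3 to compound 4 (0.27 log units; within the scatter). Compound 4 is estimated at 9 mL/min/kg, with an expected range of 5 mL/min/kg to 16 mL/min/kg.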

Compound 4, clearance in the Homo sapiens assay: 9.7 mL/min/kg
Beside the measured number, compound 4's estimate is 1.1-fold (0.03 log units) below it; the range from low to high includes it.
By their numbers in the Homo sapiens assay, from the lowest: compounds 3, 1, 4 and 2 (each within the scatter of the next, the first and the last beyond it).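

In the Homo sapiens assay, 3,5-dichlorophenyl in place of phenyl gives a 2.0-fold higher number from compound 3 to compound 4 (0.31 log units; beyond the scatter), a modest step, while 3,5-dichlorophenyl in place of 4-chlorophenyl gives a 1.0-fold lower number from compound 2 to compound 4 (0.01 log units; within the scatter), so a second chloro brings no readable change beyond the first. The carbonyl link and the saturated link also cannot be told apart when both carry 3,5-dichlorophenyl, with a 1.1-fold higher number from compound 1 to compound 4 (0.05 log units; within the scatter). In a physicochemical assay for lipophilicity, read by LC-MS, using the shake flask method, at pH 7.4 (a lower number here means a more polar compound, a higher number a more lipophilic compound), compound 3 gives 0.3 and compound 4 gives 2 and the same change from phenyl is a large one: the measured distribution coefficient of compound 3, 0.3, and of compound 4, 2, a number 1.70 log units higher (beyond the scatter)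

Open, going by these compounds, is whether a nitrile or a methoxy group on the phenyl, in place of chloro, would leave clearance near that of compound 3 or that of compound 4.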